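Methoxy in Place of Chloro: Compound 1 to Compound 4

The compounds below may be only part of what the source reports. "The series", "measured", "known", "first", "only" and "open" are said of these compounds alone.

Compound 1 `O=C(/C=C/c1cccc(Cl)c1)c1nc2ccccc2s1` is tested in a functional assay on HepG2 cells (Homo sapiens) for antiproliferative activity, read by MTT assay, with a stated time of 48 h; a lower number here means a stronger inhibitor, a higher number a weaker inhibitor. In this assay compound 1 gives only > 100000 nM, which is a limit of the assay and not a number. Compound 2 `COc1cccc(/C=C/C(O)c2nc3ccccc3[nH]2)c1` likewise returns only > 100000 nM in this assay, again a limit. Compound 3 `O=C(/C=C/c1ccncc1)c1nc2ccccc2[nH]1` gives 6940 nM in this assay. Compound 1 thus stands at the limit of > 100000 nM in this assay, at which 2 of the 3 values shown sit. Compound 4 `COc1cccc(/C=C/C(=O)c2nc3ccccc3s2)c1` differs from compound 1 by methoxy in place of chloro on an aromatic carbon. Going by the values given here, no measured pair shows this exchange on its own. The expected step, a number no higher from compound 1 to compound 4 (the limit leaves the size open), is none beyond the scatter. Compound 4 is therefore estimated to give about 100000 nM in this assay, within 20000 nM to 400000 nM, and is expected most likely to return only a limit again.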

Compound 4, half-maximal inhibitory concentration: > 100000 nM
Compound 4: only a limit was reported (the forecaster's own chance of this, stated with the estimate: 60%); the middle value sits exactly at the limit.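

Compound 1 and compound 4 each return only a limit in this assay, so no step can be read for methoxy in place of chloro on an aromatic carbon. The compounds shown leave open whether this exchange changes antiproliferative activity at all.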